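Swapping Bromo for Methoxy on a Pyrrole Chalcone

The compounds below may be only part of what the source reports. "The series", "measured", "known", "first", "only" and "open" are said of these compounds alone.

Within the data shown here, the series shares a pyrrolyl propenone core, and the three measured members differ in the aryl group attached to the double bond. Compound 1 `CCc1ccc(/C=C/C(=O)c2ccc[nH]2)o1` carries an ethylfuran, compound 2 `O=C(/C=C/c1ccc(Br)cc1)c1ccc[nH]1` a bromophenyl and compound 3 `COc1ccccc1/C=C/C(=O)c1ccc[nH]1` a methoxyphenyl. In an assay for inhibition of cytochrome P450 1A1 (Homo sapiens), read by fluorescence, using microsomes, with a stated time of 10 min (a higher number here means a weaker inhibitor, a lower number a stronger inhibitor), compound 3 gives 900 nM. For compound 2 the assay reports only a limit, > 20000 nM. For compound 1 the result is likewise a limit, > 20000 nM. Compound 2 therefore stands at the upper boundary of what this assay resolves, sharing that position with compound 1, while compound 3 alone returns a number; this is summarised by the limit of > 20000 nM in this assay, at which 2 of the 3 values shown sit.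

Compound 4 `COc1ccc(/C=C/C(=O)c2ccc[nH]2)cc1` is the next step from compound 2. The change is methoxy in place of bromo on an aromatic carbon. Among the measured compounds shown here, no measured pair shows this exact exchange, so the size of the step is open. Compound 3 shows that a methoxy-bearing phenyl can register a value in this assay, and on that basis compound 4 is expected to move toward a measurable figure, though the step could still end at a limit. Compound 4 is estimated at 6000 nM, within 1000 nM to 30000 nM. That corresponds to an expected step of an at least 3.3-fold lower number from compound 2 to compound 4 (0.52 log units; beyond the scatter).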

Compound 4, half-maximal inhibitory concentration: > 20000 nM
Compound 4 gave a limit, no number; the forecaster's own chance of this, stated with the estimate: 40%; middle value at least 3.3-fold (0.52 log units) away from the limit.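

In this assay compound 4 gives > 20000 nM, which is a limit and not a number. Compound 2 also stands at a limit, so no step from compound 2 to compound 4 can be read: the limit of > 20000 nM in this assay, at which 3 of the 4 values shown sit.

The compounds shown leave open how far methoxy in place of bromo on an aromatic carbon moves the inhibition.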